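The compounds below may be only part of what the source reports. "The series", "measured", "known", "first", "only" and "open" are said of these compounds alone.

Three compounds have been measured in an assay on cells for inhibition of Amine oxidase [flavin-containing] A (Homo sapiens), read by fluorescence and Amplex Red, with a stated time of 15 min; on this read-out higher numbers stand for weaker inhibition and lower numbers for stronger inhibition:

Compound 1, `Cc1ccc2oc(-c3ccccc3Br)cc2c1`: 11000 nM
Compound 2, `Cc1cccc2cc(-c3cccc(Br)c3)oc12`: > 100000 nM, a limit of the assay and not a number
Compound 3, `Cc1ccc2oc(-c3ccccc3)cc2c1`: > 100000 nM, a limit of the assay and not a number

Compound 1 is the only one of the three with a numerical result in this assay. Going to compound 3 makes (hydrogen in place of bromo on an aromatic carbon), and the step is an at least 9.0-fold higher number from compound 1 to compound 3 (0.95 log units; beyond the scatter). Compound 2 and compound 1 are built from the same atoms joined differently, and the difference between the two cores is not broken down here. Two of the three results sit at the limit of > 100000 nM in this assay, at which 2 of the 3 values shown sit, so compound 2 starts from a limit rather than a number.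

Compound 4, `Cc1cccc2cc(-c3ccccc3)oc12`, has not been measured. From compound 2 it makes (hydrogen in place of bromo on an aromatic carbon). This is the same kind of change as that from compound 1 to compound 3, but not the same: there the bromo stood ortho to a large group, here it stands meta to a large group. In the one measured case the loss of bromo weakened inhibition, and compound 2 already rests at the limit of this assay. Compound 4 is therefore expected to come out at 300000 nM, most likely again reported only as a limit, with a range from 80000 nM to 2000000 nM. The expected step is a step that the limit leaves unreadable from compound 2 to compound 4, an estimate that rests on an at least 9.0-fold higher number from compound 1 to compound 3 (0.95 log units; beyond the scatter) and on the limit already given for compound 2.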

Compound 4, half-maximal inhibitory concentration: 100000 nM
The estimate for compound 4 lay 3.0-fold (0.48 log units) above the measured number; low and high end bracket the measured number.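

In this assay, hydrogen in place of bromo on an aromatic carbon gives a number no higher from compound 2 to compound 4 (the limit leaves the size open), and the change does not repeat what it did on the core of compound 1: the same change on two cores in this assay, an at least 9.0-fold higher number (0.95 log units; beyond the scatter) from compound 1 to compound 3 and a number no higher (the limit leaves the size open) from compound 2 to compound 4, at least 9.0-fold (0.95 log units) apart, beyond the scatter of two such steps. Compound 2 stands at > 100000 nM, which is a limit of the assay and not a number. The result shows that the gain in inhibition linked to bromo on the core of compound 1 cannot simply be assumed on the core of compound 2, but it does not show whether the core or the place of the bromo accounts for the difference, since the two pairs differ in both, and it gives no size for the step on the core of compound 2.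

The compounds shown leave open whether bromo would help on the core of compound 4 if it stood at the place it holds in compound 1, and so whether the two cores really respond differently. They also leave open whether another group at that place, such as chloro, methoxy or an amine, would match or exceed the inhibition that compound 1 shows.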